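The compounds below may be only part of what the source reports. "The series", "measured", "known", "first", "only" and "open" are said of these compounds alone.

Measured so far:
- compound 1 `FC(F)(F)c1ccc(CSc2nc(Nc3ccccc3Cl)c3ccccc3n2)cc1`; in a functional assay on MCF7 cells (Homo sapiens) for cytotoxicity, read by MTT assay, with a stated time of 72 h (on this read-out lower numbers stand for stronger inhibition and higher numbers for weaker inhibition), compound 1 gives > 50000 nM, which is a limit of the assay rather than a number.
- compound 2 `FC(F)(F)c1ccc(CSc2nc(Nc3ccc(Cl)cc3)c3ccccc3n2)cc1`; in this assay compound 2 gives 21500 nM.

Compound 1 thus sits at the limit of > 50000 nM in this assay, at which 1 of the 2 values shown sits, so only a boundary is known for it. Compound 3 `Fc1ccc(Nc2nc(SCc3ccc(C(F)(F)F)cc3)nc3ccccc23)cc1Cl` differs from compound 1 by 3-chloro-4-fluorophenyl in place of 2-chlorophenyl on a nitrogen on an aromatic ring. Among the measured compounds shown here, the one measured step that bears on this, an at least 2.3-fold lower number from compound 1 to compound 2 (0.36 log units; beyond the scatter), also moved the chlorine away from the position it holds in compound 1 and gave a lower number. A lower number is therefore expected for compound 3 as well, roughly an at least 2.5-fold lower number from compound 1 to compound 3 (0.39 log units; beyond the scatter). The estimate for compound 3 in this assay is 20000 nM, within 7000 nM to 50000 nM.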

Compound 3, half-maximal inhibitory concentration: 23000 nM
Estimate against measurement, compound 3: 1.2-fold (0.06 log units) below, within the range that was stated.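

On the nitrogen on an aromatic ring, another replacement for 2-chlorophenyl also lowers the number in this assay, with an at least 2.1-fold lower number from compound 1 to compound 3 (0.33 log units; beyond the scatter). As far as these compounds go, compound 1 gives only a limit, so the true size of this step stays unknown: the limit of > 50000 nM in this assay, at which 1 of the 3 values shown sits. The 3-chloro-4-fluorophenyl and 4-chlorophenyl groups cannot be told apart here, with a 1.1-fold higher number from compound 2 to compound 3 (0.03 log units; within the scatter).

Still open, from the compounds shown here alone, is whether a plain phenyl, without any halogen, would give a similar number at this nitrogen. Going by these compounds, it is equally open how a phenyl carrying a methoxy group, an amine or a carboxylic acid would behave.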